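Replacing Fluoro with tert-Butyl on an Aromatic Carbon

This account rests on a few compounds, and the source may have more. Where it says the series, first, only, none or still open, it means among the compounds named here.

In a functional assay on A549 cells (Homo sapiens) for inhibition, read by CCK-8 assay, with a stated time of 72 h, tested at 2 uM (a lower number here means less inhibition of growth, a higher number more inhibition of growth at the concentration tested), compound 1 (`Cc1cc(C)cc(SCc2ccc(/C=C/C(=O)Nc3ccccc3N)cc2)c1`) gives 46.1% growth inhibition and compound 2 (`Nc1ccccc1NC(=O)/C=C/c1ccc(CSc2ccc(Cl)cc2)cc1`) gives 55.3% growth inhibition. Compound 3 (`Nc1ccccc1NC(=O)/C=C/c1ccc(CSc2ccc(F)cc2)cc1`) gives 51.2% growth inhibition, which places it among the other two without a separation beyond the scatter from either. The next compound, compound 4 (`CC(C)(C)c1ccc(SCc2ccc(/C=C/C(=O)Nc3ccccc3N)cc2)cc1`), has not yet been measured. It carries tert-butyl in place of fluoro on an aromatic carbon, para to a large group (tert-butyl in place of fluoro on an aromatic carbon). Among the compounds with values here, three measured steps bear on this change. Changing the group on the sulfur gave a number 9.2 percentage points higher from compound 1 to compound 2 (within the scatter) and a number 5.1 percentage points higher from compound 1 to compound 3 (within the scatter) on the way to the two halogenated compounds, while exchanging the halogen gave a number 4.1 percentage points lower from compound 2 to compound 3 (within the scatter) in the same series. Within the data shown here, all three are small, but no measured compound carries tert-butyl, so the data do not test this group directly. The closest guide is compound 1, whose 3,5-dimethylphenyl on the sulfur still gives 46.1% growth inhibition. The expected change is a number 4.2 percentage points lower from compound 3 to compound 4 (within the scatter) and it is not expected to exceed the scatter. For compound 4 the estimate is 47% growth inhibition, with an expected range from 33% to 61% growth inhibition.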

Compound 4, percent growth inhibition at one concentration: 71.5%
For compound 4 the middle estimate is 24.5 percentage points below the measured one; the whole stated range lies below it.
By their numbers in this assay, from the lowest: compounds 1, 3 and 2 (each within the scatter of the next); then compound 4.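

In this assay, within the data shown here, exchanges among the groups on the aromatic ring attached to the sulfur had so far stayed within the scatter, but tert-butyl at this place, para to a large group, gives a number 20.3 percentage points higher from compound 3 to compound 4 (beyond the scatter) and so opens the first clear separation. The separation is not specific to the comparison with fluoro: tert-butyl in place of chloro gives a number 16.2 percentage points higher from compound 2 to compound 4 (beyond the scatter) and 4-(tert-butyl)phenyl in place of 3,5-dimethylphenyl on the sulfur gives a number 25.4 percentage points higher from compound 1 to compound 4 (beyond the scatter), which makes compound 4 the most active of the four at the concentration tested. Nothing available gives a reason for this separation.

From the compounds shown here alone, whether the gain belongs to tert-butyl alone or would also appear with isopropyl, cyclopropyl or trifluoromethyl at this place stays open, as does the effect of an amine or a carboxylic acid there. With one cell line and one concentration in view, the compounds shown also leave open how far the separation of compound 4 carries over to other concentrations or other cells.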